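Swapping the Aryl Amide in a Phosphodiesterase Series

A few compounds are considered here, and "the series" means these few. Any claim that something is new, unique, unknown or untested is made for them only; others in the source may bear on it.

Three compounds share one core and differ in the chain that joins it to an amide, and in the aryl group on the amide nitrogen. Compound 1 `COc1nc2c(c(=O)n(C)c(=O)n2C)n1CC(=O)Nc1cccc(Cl)c1` carries a 3-chlorophenyl group on a short chain. In an assay on isolated protein for inhibition of high affinity 3',5'-cyclic-AMP phosphodiesterase 7A (Homo sapiens), read by cAMP accumulation, with a stated time of 10 min (on this read-out higher numbers stand for weaker inhibition and lower numbers for stronger inhibition), compound 1 gives only a limit, > 200000 nM. Compound 2 `COc1nc2c(c(=O)n(C)c(=O)n2C)n1CC(=O)Nc1ccc(C(C)(C)C)cc1` places a 4-tert-butylphenyl group on the same short chain; in this assay compound 2 likewise reaches only a limit, > 200000 nM. Compound 3 `COc1nc2c(c(=O)n(C)c(=O)n2C)n1CCCC(=O)Nc1cccc(Cl)c1` keeps the 3-chlorophenyl group on a longer chain, and in this assay compound 3 again gives only a limit, > 200000 nM. All three values sit at one point, (the limit of > 200000 nM in this assay, at which 3 of the 3 values shown sit), so compound 3 stands level with the others and no ranking among them is possible. Compound 4 `COc1nc2c(c(=O)n(C)c(=O)n2C)n1CCCC(=O)Nc1ccc(C(C)C)cc1` is compound 3 with 4-isopropylphenyl in place of 3-chlorophenyl on an amide-type nitrogen. Compound 2 already shows a 4-tert-butylphenyl group at the same limit, so no measurable step is expected. The expected step that the limit leaves unreadable from compound 3 to compound 4 is none beyond the scatter. Compound 4 is expected to give 300000 nM, within a range from 100000 nM to 1000000 nM, most likely again as a limit.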

Compound 4, half-maximal inhibitory concentration: > 200000 nM
Compound 4: no number, only a limit (the forecaster's own chance of this, stated with the estimate: 85%); the middle value is on the limit's open side.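

In this assay compound 4 gives only a limit (> 200000 nM). For the compounds shown here, compound 3 also gives only a limit, so no step from compound 3 to compound 4 can be read. The compounds shown leave open which aryl group or chain, if any, would give a measurable value.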